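This account rests on a few compounds, and the source may have more. Where it says the series, first, only, none or still open, it means among the compounds named here.

Compound 1 `CC1=C(SCCCO)C(=O)c2ccccc2C1=O` gives 9530 nM in a functional assay on HepG2 cells (Homo sapiens) for inhibition; on this read-out lower numbers stand for stronger inhibition and higher numbers for weaker inhibition. Compound 2 `CC1=C(SCCCCCCO)C(=O)c2ccccc2C1=O` gives > 10000 nM, which is a limit of the assay and not a number.

Compound 2 thus stands at the limit of > 10000 nM in this assay, at which 1 of the 2 values shown sits, so only a limit is known for it. Compound 3 `CC1=C(SC(C)C(C)O)C(=O)c2ccccc2C1=O` differs from compound 2 in one place: 2-hydroxy-1-methylpropyl in place of 6-hydroxyhexyl on a sulfur. Going by the values given here, the only measured step, an at least 1.0-fold higher number from compound 1 to compound 2 (0.02 log units; that floor lies within the scatter), replaced one hydroxyalkyl chain by another and stayed within the scatter. Compound 3 is therefore expected to show no step beyond the scatter, an at least 1.1-fold lower number from compound 2 to compound 3 (0.04 log units; that floor lies within the scatter). Compound 3 is estimated at 9000 nM, with a range from 3000 nM to 30000 nM.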

Compound 3, half-maximal inhibitory concentration: > 10000 nM
Compound 3: a limit, no number; the forecaster's own chance of this, stated with the estimate: 45%; at least 1.1-fold (0.04 log units) between middle value and limit.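

In this assay, putting 2-hydroxy-1-methylpropyl in place of 3-hydroxypropyl on the sulfur gives an at least 1.0-fold higher number from compound 1 to compound 3 (0.02 log units; that floor lies within the scatter). The step from compound 2 to compound 3 cannot be read, as both values are limits of the assay. A branched hydroxyalkyl group on the sulfur now sits at the same limit as the 6-hydroxyhexyl chain: the limit of > 10000 nM in this assay, at which 2 of the 3 values shown sit.

From the compounds shown here alone, how far compound 2 and compound 3 truly lie from each other stays open. So does what an amine or a carboxylic acid would give in place of the hydroxyalkyl group on the sulfur.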